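Quaternary ammonium chain variants on a shared amide core

A few compounds are considered here, and "the series" means these few. Any claim that something is new, unique, unknown or untested is made for them only; others in the source may bear on it.

Compound 1 `Cc1ccc(-n2cc(C(=O)Nc3cc(F)cc(F)c3)c(=O)c3ccc(N(C)C)nc32)cc1OCCCCCCC[N+]1(C)CCN(C)CC1` gives 10.4% in an assay on LX2 cells for inhibition of COL1A1 promoter (Homo sapiens), read by a luciferase reporter, with a stated time of 24 h, tested at 20 uM; a higher number here means a stronger effect of the compound at the concentration tested, a lower number a weaker effect. Compound 2 `CN1CC[N+](C)(CCCCCCCOc2cc(-n3cc(C(=O)Nc4cc(F)cc(F)c4)c(=O)c4ccc(N(C)C)nc43)ccc2Cl)CC1` gives 27.5% in this assay. Compound 3 `CC[N+]1(CCCCCCCOc2cc(-n3cc(C(=O)Nc4cc(F)cc(F)c4)c(=O)c4ccc(N(C)C)nc43)ccc2C)CCCC1` gives 57% in this assay, the highest of the three measured numbers. Compound 4 `CC[N+]1(CCCCCCCOc2cc(-n3cc(C(=O)Nc4cc(F)cc(F)c4)c(=O)c4ccc(N(C)C)nc43)ccc2Cl)CCCC1` is not yet measured.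

The change chloro in place of methyl on an aromatic carbon gave a step of a number 17.1 percentage points higher from compound 1 to compound 2 (beyond the scatter). The change a group of 7 heavy atoms (6 carbon, 1 nitrogen; one five-membered non-aromatic ring with 1 hetero atom) in place of a group of 8 heavy atoms (6 carbon, 2 nitrogen; one six-membered non-aromatic ring with 2 hetero atoms), on a saturated chain carbon, seven bonds along the chain from an oxygen on an aromatic ring gave a step of a number 46.6 percentage points higher from compound 1 to compound 3 (beyond the scatter), which is how the core of compound 3 differs from the core of compound 1.

The change from compound 3 to compound 4 is chloro in place of methyl on an aromatic carbon, occurring at a place described in the same words as for the pair of compound 1 and compound 2; it is therefore the same change, carried out on a different core. Only one earlier occurrence is available, so the transfer rests on a single pair.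

For compound 4 a step of a number 13 percentage points higher from compound 3 to compound 4 (beyond the scatter) is expected in this assay, resting on the step of a number 17.1 percentage points higher from compound 1 to compound 2 (beyond the scatter) that the same change made. The estimate for compound 4 is 70%, with a range from 50% to 88%.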

Compound 4, a percentage reported as inhibition, at one concentration (the size of the read-out at that concentration, not a potency): 46%
For compound 4 the middle estimate is 24 percentage points above the measured one; the measured number lies below the stated range.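

In this assay, chloro in place of methyl gives a step of a number 11 percentage points lower from compound 3 to compound 4 (beyond the scatter), so the direction of this change did not carry from one core to the other: the same change on two cores in this assay, a number 17.1 percentage points higher (beyond the scatter) from compound 1 to compound 2 and a number 11 percentage points lower (beyond the scatter) from compound 3 to compound 4, 28.1 percentage points apart, beyond the scatter of two such steps

The exchange of the group at the end of the chain keeps its direction but not its size, with a step of a number 18.5 percentage points higher from compound 2 to compound 4 (beyond the scatter): the same change on two cores in this assay, a number 46.6 percentage points higher (beyond the scatter) from compound 1 to compound 3 and a number 18.5 percentage points higher (beyond the scatter) from compound 2 to compound 4, 28.1 percentage points apart, beyond the scatter of two such steps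

These two gaps come from a single set of four compounds, so they show that the two changes do not simply add in this series, but they do not show why the chloro step reverses or which pairing would hold on further cores.

As far as these compounds go, whether the reversal extends to other groups on that aromatic carbon, such as fluoro or methoxy, remains open. Also open, from the compounds shown here alone, is how the two changes behave with a piperidinium or trimethylammonium group at the chain end, or with a shorter chain.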